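A few compounds are considered here, and "the series" means these few. Any claim that something is new, unique, unknown or untested is made for them only; others in the source may bear on it.

Measured so far in a physicochemical assay for solubility, read by HPLC, in phosphate buffer, measured as kinetic solubility, at pH 7.4; on this read-out higher numbers stand for higher solubility and lower numbers for lower solubility:
- compound 1 `CCC(=O)c1cc(-c2ccc(S(N)(=O)=O)cc2)n(-c2ccc(C(F)(F)F)cc2)n1`: 7500 nM
- compound 2 `CCC(=O)c1cc(-c2ccc(S(N)(=O)=O)cc2)n(-c2ccc(F)cc2)n1`: 96800 nM

Compound 2 holds the higher of the two numbers at 96800 nM and is the starting point here. The next compound is compound 3 `CCC(=O)c1cc(-c2ccc(S(N)(=O)=O)cc2)n(-c2ccccc2Cl)n1`, which has not yet been measured. It carries 2-chlorophenyl in place of 4-fluorophenyl on an aromatic nitrogen and otherwise keeps the core of compound 2.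

Among the measured compounds shown here, only one measured step bears on this change. The step of a 13-fold higher number from compound 1 to compound 2 (1.11 log units; beyond the scatter) is large and exchanges fluoro for trifluoromethyl on an aromatic carbon of the ring that now changes. For the measured compounds named here, no measured compound carries chloro, and none has a substituent in the place it occupies in compound 3, so that step gives only a rough guide to size.

Compound 1 at 7500 nM shows how far the number can lie from that of compound 2 with another group on this ring, so a smaller fall is expected in this assay here. The expected change is a 2.4-fold lower number from compound 2 to compound 3 (0.38 log units; beyond the scatter) and this is an estimate of moderate size. The estimated value for compound 3 is 40000 nM with an expected range of 12000 nM to 110000 nM at this stage.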

Compound 3, solubility: 4700 nM
Beside the measured number, compound 3's estimate is 8.5-fold (0.93 log units) above it; the measured number lies below the stated range.
By their numbers in this assay, from the lowest: compounds 3 and 1 (each within the scatter of the next); then compound 2.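

In this assay, among the compounds shown here, 2-chlorophenyl in place of 4-fluorophenyl on the aromatic nitrogen gives a 21-fold lower number from compound 2 to compound 3 (1.31 log units; beyond the scatter) and is the first change to alter where the substituent sits on this ring as well as which substituent it is. Compound 3 at 4700 nM and compound 1 at 7500 nM lie within the scatter of each other, so 2-chlorophenyl and the ring bearing trifluoromethyl stand at one level, while compound 2 alone stands apart from both by a large step. No measurement among those shown accounts for this step.

The change joins two differences, chloro for fluoro and a new place on the ring, and the compounds shown do not separate them, since neither 4-chlorophenyl nor 2-fluorophenyl is among them. Also open, as far as these compounds go, is where this assay would place a phenyl bearing an amine or a carboxylic acid on this same aromatic nitrogen.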